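The compounds below may be only part of what the source reports. "The series", "measured", "known", "first", "only" and "open" are said of these compounds alone.

Measured compounds:
- compound 1, `COc1ccc(F)cc1CNCCCNc1ccnc2cc(C3CCCCC3)ccc12`: 2290 nM
- compound 2, `COc1ccc(Oc2ccc3c(NCCCNCc4cc(F)ccc4OC)ccnc3c2)cc1`: 7000 nM
- compound 3, `COc1cccc(Oc2ccc3c(NCCCNCc4cc(F)ccc4OC)ccnc3c2)c1`: 7100 nM

In an ADME assay on HepG2 cells (Homo sapiens) for cytotoxicity, read by luminescence, CellTiter-Glo and ATP content, with a stated time of 72 h (on this read-out higher numbers stand for an effect only at larger amounts of compound and lower numbers for an effect already at smaller amounts), compound 3 holds the highest number of the three, although compound 2 sits within the scatter of it, as a 1.0-fold higher number from compound 2 to compound 3 (0.01 log units; within the scatter) shows; the gap to compound 1 is larger, a 3.1-fold higher number from compound 1 to compound 3 (0.49 log units; beyond the scatter). The two aryloxy compounds are set apart from the cyclohexyl compound, a 3.1-fold higher number from compound 1 to compound 2 (0.49 log units; beyond the scatter) and a 3.1-fold higher number from compound 1 to compound 3 (0.49 log units; beyond the scatter), while moving the methoxy group around the phenoxy ring made no difference beyond the scatter.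

Compound 4, `COc1ccc(F)cc1CNCCCNc1ccnc2cc(Oc3cccc(N(C)C)c3)ccc12`, differs from compound 3 in one place: dimethylamino in place of methoxy on an aromatic carbon. Among the measured compounds shown here, no measured step swaps one of these two groups for the other, so the expectation rests on the nearest comparison, the small change on the same phenoxy ring from compound 2 to compound 3, which gave a 1.0-fold higher number from compound 2 to compound 3 (0.01 log units; within the scatter). The shared core and the phenoxy attachment stay as in compound 3. On that basis, a step of a 1.0-fold lower number from compound 3 to compound 4 (0.01 log units; within the scatter) in this assay is expected, that is, nothing beyond the scatter. Compound 4 is therefore estimated at 7000 nM in this assay, with a range from 3500 nM to 15000 nM.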

Compound 4, half-maximal effective concentration: 3300 nM
The estimate for compound 4 lay 2.1-fold (0.33 log units) above the measured number; the measured number lies below the stated range.
By their numbers in this assay, from the lowest: compounds 1 and 4 (each within the scatter of the next); then compounds 2 and 3 (each within the scatter of the next).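

Swapping the group on this phenoxy ring has an effect that moving it did not: in this assay, dimethylamino in place of methoxy, on the aromatic carbon meta to a large group, gives a 2.2-fold lower number from compound 3 to compound 4 (0.33 log units; beyond the scatter), so cell toxicity appears at smaller amounts of compound, and the comparison with the 4-methoxyphenoxy compound agrees, with a 2.1-fold lower number from compound 2 to compound 4 (0.33 log units; beyond the scatter). The earlier gap between the aryloxy compounds and the cyclohexyl compound therefore does not hold for every aryloxy group, since the step to the dimethylamino compound, a 1.4-fold higher number from compound 1 to compound 4 (0.16 log units; within the scatter), stays within the scatter, and compound 4 goes against any rule that an aryloxy group in place of cyclohexyl raises the number. Nothing measured here explains why dimethylamino and methoxy differ on this ring.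

From the compounds shown here alone, it remains open whether the lower number is particular to dimethylamino or would also come with another amine on the same carbon, such as a plain amino group or a pyrrolidine ring. A hydroxyl group or a carboxylic acid at this place could show whether the number can instead move upward from that of compound 3, at 7100 nM.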